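Ester to acid in a peroxide series on L1210 cells

The compounds below may be only part of what the source reports. "The series", "measured", "known", "first", "only" and "open" are said of these compounds alone.

Measured so far:
compound 1 `CC(CCCC/C=C/CC/C=C\c1ccccc1)C[C@]1(C)C[C@@](C)(CC(=O)O)OO1`, 0.017 ug/mL
compound 2 `COC(=O)C[C@@]1(C)C[C@@](C)(CC(C)CCCC/C=C/CC/C=C\c2ccccc2)OO1`, 0.29 ug/mL

In a functional assay on L1210 cells (Mus musculus) for cytotoxicity (a higher number here means a weaker inhibitor, a lower number a stronger inhibitor), compound 2 gives the highest of the two numbers; compound 1 gives a lower number, and the two differ in more than one place, so only their values are compared here. Compound 3 `CC(CCCC/C=C/CC/C=C\c1ccccc1)C[C@]1(C)C[C@](C)(CC(=O)O)OO1` differs from compound 2 in one place: hydrogen in place of methyl on an oxygen next to a carbonyl group. Among the measured compounds shown here, no measured pair isolates this change. A step downward, beyond the scatter, is expected, since compound 1, also a carboxy compound, gives 0.017 ug/mL. Compound 3 is estimated at 0.04 ug/mL (range 0.01 ug/mL to 0.2 ug/mL), an expected step of a 7.3-fold lower number from compound 2 to compound 3 (0.86 log units; beyond the scatter).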

Compound 3, half-maximal inhibitory concentration: 0.052 ug/mL
For compound 3 the middle estimate is 1.3-fold (0.11 log units) below the measured one, and the stated range covers the measured number.
By their numbers in this assay, from the lowest: compound 1; then compound 3; then compound 2.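

In this assay, among the compounds shown here, methoxycarbonyl to carboxy gives the only step that isolates this group, a 5.6-fold lower number from compound 2 to compound 3 (0.75 log units; beyond the scatter), so here the carboxy form gives the lower number. The same atoms and bonds, with a stereocentre at a saturated ring carbon drawn R rather than S, give a 3.1-fold higher number from compound 1 to compound 3 (0.49 log units; beyond the scatter), so the drawn configuration also goes with a change beyond the scatter. That reading carries one caveat: the fact that one of compounds 1 and 3 is drawn with a defined configuration and the other without, at the place where they differ. Open, as far as these compounds go, is whether the ester-to-acid step holds at the other configuration, and whether a primary amide or a longer chain bearing the carboxy group would keep the lower number.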